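A few compounds are considered here, and "the series" means these few. Any claim that something is new, unique, unknown or untested is made for them only; others in the source may bear on it.

Working notes on the series: in a functional assay on HL-60 cells (Homo sapiens) for inhibition (a lower number here means a stronger inhibitor, a higher number a weaker inhibitor), compound 1 (`COc1ccc(-c2cc(=O)n(C(C)C)nc2-c2ccc(OC)cc2)cc1`) gives 1320 nM, and compound 2 (`COc1ccc(-c2cc(=O)n(C3CC3)nc2-c2ccc(OC)cc2)cc1`) gives 7980 nM, the higher of the two numbers. Compound 3 (`COc1ccc(-c2cc(=O)n(CC3CC3)nc2-c2ccc(OC)cc2)cc1`) brings cyclopropylmethyl in place of cyclopropyl on an aromatic nitrogen. Among the measured compounds shown here, the only measured change at this nitrogen is a 6.0-fold higher number from compound 1 to compound 2 (0.78 log units; beyond the scatter), a modest step. For the measured compounds named here, no measured compound carries cyclopropylmethyl, so that step sets only the likely scale. A modest move toward a lower number in this assay is expected, giving a 2.7-fold lower number from compound 2 to compound 3 (0.42 log units; beyond the scatter) as the estimated step. The estimated value for compound 3 is 3000 nM, with a range of 900 nM to 9000 nM.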

Compound 3, half-maximal inhibitory concentration: 1800 nM
The estimate for compound 3 lay 1.7-fold (0.22 log units) above the measured number; the measured number falls inside the stated range.
By their numbers in this assay, from the lowest: compounds 1 and 3 (each within the scatter of the next); then compound 2.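

In this assay, the three-membered ring alone does not set the higher number of compound 2: cyclopropylmethyl keeps that ring and gives a 4.4-fold lower number from compound 2 to compound 3 (0.65 log units; beyond the scatter). Against isopropyl, cyclopropylmethyl gives a 1.4-fold higher number from compound 1 to compound 3 (0.13 log units; within the scatter), so these two groups cannot be told apart here. Nothing available accounts for the difference between these groups. Open, from the compounds shown here alone, is how a longer chain such as butyl, or an amine such as aminoethyl, would behave on this nitrogen. Also open, going by these compounds, is whether these steps would hold with the two 4-methoxyphenyl groups replaced.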